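The source may report more compounds than this note shows. Statements on the series, on what has been measured and on what is new or still open speak of the compounds shown alone.

Measured in a functional assay on HCT-8 cells (Homo sapiens) for cytotoxicity; on this read-out lower numbers stand for an effect already at smaller amounts and higher numbers for an effect only at larger amounts of compound:

Compound 1 `COC1=C(C)C(=O)/C(=C(O)/C=C/c2ccc(Br)cc2)C(=O)C1(C)C`: 7.4 ug/mL
Compound 2 `COC1=C(C)C(=O)/C(=C(O)/C=C/c2ccccc2OC)C(=O)C1(C)C`: 4.1 ug/mL
Compound 3 `COC1=C(C)C(=O)/C(=C(O)/C=C/c2c(C)cccc2C)C(=O)C1(C)C`: 7.8 ug/mL

These three compounds share a core and differ only in one group. Compound 3, with its 7.8 ug/mL, lies within the scatter of both others: the steps are a 1.1-fold higher number from compound 1 to compound 3 (0.02 log units; within the scatter) and a 1.9-fold higher number from compound 2 to compound 3 (0.28 log units; within the scatter). Compound 4 `COC1=C(C)C(=O)/C(=C(O)/C=C/c2ccco2)C(=O)C1(C)C` carries furan-2-yl in place of 2,6-dimethylphenyl on a double-bonded chain carbon bound to a double-bonded chain carbon. Among the compounds with values here, no measured compound here carries furan-2-yl, so the evidence is indirect. Within the data shown here, the steps that bear on this change are exchanges of group at that same place. Besides the two above, there is a 1.8-fold lower number from compound 1 to compound 2 (0.26 log units; within the scatter). Going by these compounds, all three stay within the scatter, so no step beyond the scatter is expected in this assay, and the direction remains open. The expected step is a 1.4-fold lower number from compound 3 to compound 4 (0.15 log units; within the scatter). For compound 4 the estimated value is 5.5 ug/mL, with an expected range from 2.5 ug/mL to 12 ug/mL.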

Compound 4, concentration for half-maximal effect: 17.5 ug/mL
Estimate against measurement, compound 4: 3.2-fold (0.50 log units) below, outside the stated range (above it).
By their numbers in this assay, from the lowest: compounds 2, 1 and 3 (each within the scatter of the next); then compound 4.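

In this assay furan-2-yl alone among the four groups at this place separates from the others, with a 2.2-fold higher number from compound 3 to compound 4 (0.35 log units; beyond the scatter) against 2,6-dimethylphenyl, a 2.4-fold higher number from compound 1 to compound 4 (0.37 log units; beyond the scatter) against 4-bromophenyl and a 4.3-fold higher number from compound 2 to compound 4 (0.63 log units; beyond the scatter) against 2-methoxyphenyl. The three substituted phenyl groups stay within the scatter of one another, so the exchange that matters here is that of a six-membered aromatic ring of carbon only for a five-membered aromatic ring with a hetero atom, which from compound 3 to compound 4 also brings fewer heavy atoms and a hydrogen-bond acceptor. No measurement at hand explains the step or tells these differences apart.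

The compounds leave open whether the higher number belongs to furan-2-yl alone or also to a ring such as thiophene-2-yl, which has sulfur in place of the ring oxygen. They also leave open how an unsubstituted phenyl or a phenyl carrying an amine would behave at this place.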